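The compounds below may be only part of what the source reports. "The series", "measured", "known", "first", "only" and "open" are said of these compounds alone.

Measured compounds:

Compound 1 `Cc1cc(NC(=O)Nc2ccc(F)c(F)c2)c2ccccc2n1` in an ADME assay on HepG2 cells (Homo sapiens) for cytotoxicity, with a stated time of 72 h (a lower number here means that less compound is needed, a higher number that more compound is needed for the effect), gives 21000 nM.
Compound 2 `Cc1cc(NC(=O)Nc2ccc(F)cc2)c2ccccc2n1` in this assay gives > 25000 nM, a limit of the assay.
Compound 3 `Cc1cc(NC(=O)Nc2ccccc2F)c2ccccc2n1` in this assay gives > 25000 nM, a limit of the assay.

All three share one core; what sets them apart sits on the ring attached to the urea. Compound 2 and compound 3 hold the same atoms joined differently: 2-fluorophenyl in place of 4-fluorophenyl on an amide-type nitrogen. In this assay the step from one to the other is a step that the two limits leave unreadable from compound 2 to compound 3, because the limit of > 25000 nM in this assay, at which 2 of the 3 values shown sit, hides any difference between them.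

From compound 2 to compound 1 the change is fluoro in place of hydrogen on an aromatic carbon, and the step is an at least 1.1-fold lower number from compound 2 to compound 1 (0.07 log units; that floor lies within the scatter).

The unmeasured compound 4 `Cc1cc(NC(=O)Nc2cc(F)ccc2F)c2ccccc2n1` arises from compound 3 by fluoro in place of hydrogen on an aromatic carbon. This is the same kind of change as from compound 2 to compound 1, not the same one: there the entering fluoro sat ortho to a fluoro group and meta to a large group, here it sits meta to a large group and para to a fluoro group.

Going by the values given here, since the one measured instance of this kind of change gave only an at least 1.1-fold lower number from compound 2 to compound 1 (0.07 log units; that floor lies within the scatter), the expected step from compound 3 to compound 4 is small, an at least 1.0-fold lower number from compound 3 to compound 4 (0.01 log units; that floor lies within the scatter). Compound 4 is therefore expected to give about 24000 nM in this assay, estimated between 12000 nM and 50000 nM, with a fair chance that only a limit is reported again.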

Compound 4, half-maximal effective concentration: > 25000 nM
Compound 4 was reported as a limit; the forecaster's own chance of this, stated with the estimate: 55%; at least 1.0-fold (0.01 log units) between middle value and limit.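

No size can be given for the step between compound 3 and compound 4, because both compounds stand at the same limit of the assay: the limit of > 25000 nM in this assay, at which 3 of the 4 values shown sit.

The compounds shown leave open whether the fluoro entering compound 4 changes the number in this assay at all, and how compound 2, compound 3 and compound 4 rank against one another, with all three reported only as limits.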